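Swapping the Bromobenzyl Thioether in a Nucleoside Series

A few compounds are considered here, and "the series" means these few. Any claim that something is new, unique, unknown or untested is made for them only; others in the source may bear on it.

Three nucleoside analogues have been measured in an assay on isolated protein for binding affinity to Equilibrative nucleoside transporter 1 (Homo sapiens); on this read-out higher numbers stand for weaker inhibition and lower numbers for stronger inhibition. Compound 1, `O=[N+]([O-])c1cccc2c1CN(c1ncnc3c1nc1n3[C@@H]3O[C@H](CO1)[C@@H](O)[C@H]3O)CC2`, gives 1740000 nM in this assay. Compound 2, `OC[C@H]1O[C@@H](n2cnc3c(Sc4ccccc4)ncnc32)[C@H](O)[C@@H]1O`, gives 91200 nM. Compound 3, `Nc1nc(SCc2cccc(Br)c2)c2ncn([C@@H]3O[C@H](CO)[C@@H](O)[C@H]3O)c2n1`, gives 2880 nM, the lowest of the three numbers, and it stands beyond the scatter from both of the others: the nearest value is that of compound 2, and compound 1 lies furthest away. With its amino group on the shared core and the sulfur-linked aryl group, compound 3 therefore stands out as the strongest binder among the compounds measured here.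

Compound 4, `Nc1nc(SCCc2ccccc2)c2ncn([C@@H]3O[C@H](CO)[C@@H](O)[C@H]3O)c2n1`, has not yet been measured. It differs from compound 3 in one place: benzyl in place of 3-bromophenyl on a saturated chain carbon bound to a sulfur. The bromine is thus gone and the aromatic ring is moved one saturated carbon further from the sulfur.

Going by the values given here, no step between measured compounds shows what such a change does, so the expectation rests on compound 3 alone. A small loss of binding seems the more likely outcome, roughly the size of a step from compound 3 to compound 4 of a 2.1-fold higher number from compound 3 to compound 4 (0.32 log units; beyond the scatter), which stays close to the scatter. Compound 4 is therefore estimated at 6000 nM in this assay, within a range from 1500 nM to 25000 nM.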

Compound 4, half-maximal inhibitory concentration: 16200 nM
For compound 4 the middle estimate is 2.7-fold (0.43 log units) below the measured one, and the stated range covers the measured number.
By their numbers in this assay, from the lowest: compound 3; then compound 4; then compound 2; then compound 1.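

In this assay, exchanging 3-bromobenzyl for phenethyl on the sulfur gives a 5.6-fold higher number from compound 3 to compound 4 (0.75 log units; beyond the scatter), so the group at this position can move the read-out beyond the scatter. This happens even though the pieces that leave and enter hold the same number of heavy atoms and each carries one six-membered aromatic ring of carbon only. Going by these compounds alone, the single step joins two changes, as the bromine is lost and the ring sits one saturated carbon further from the sulfur, and nothing available here explains the weaker inhibition.

The compounds shown do not separate those two changes: an unsubstituted benzyl group on the sulfur would isolate the loss of the bromine, and a 3-bromophenethyl group would isolate the longer link. They also leave open how a longer chain, such as phenylpropyl, or a ring bearing an amine or a carboxylic acid in place of the bromine, would read in this assay.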